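The source may hold more compounds than are shown below. What is called first, only, known or untested is meant among the compounds shown, and "the series" means these compounds.

Four compounds built on one shared core were compared in a functional assay on PANC-1 cells (Homo sapiens) for inhibition, read by MTT assay, with a stated time of 24 h, tested at 10 uM; a higher number here means more inhibition at the concentration tested (going by the name of the read-out), a lower number less inhibition. Compound 1, `CC(C)=CCC1Cc2c(OCCCNC(=O)c3ccco3)cc(=O)n(CCCO)c2CC1(C)C`, carries a furan-2-yl group on the carbonyl carbon of its amide, and in this assay compound 1 gives 2.1%. Compound 2, `CC(C)=CCC1Cc2c(OCCCNC(=O)c3cccs3)cc(=O)n(CCCO)c2CC1(C)C`, differs from compound 1 only in that (thiophen-2-yl in place of furan-2-yl on a carbonyl carbon); in this assay compound 2 gives 33.6%, and that exchange made a step of a number 31.5 percentage points higher from compound 1 to compound 2 (beyond the scatter). Compound 3, `CC(C)=CCC/C(C)=C/CC1Cc2c(OCCCNC(=O)c3ccco3)cc(=O)n(CCCO)c2CC1(C)C`, keeps the furan-2-yl group of compound 1 but its core differs in that (3-methylbut-2-en-1-yl in place of hydrogen on a saturated chain carbon bound to a double-bonded chain carbon); in this assay compound 3 gives 69.5%, a step of a number 67.4 percentage points higher from compound 1 to compound 3 (beyond the scatter), and compound 3 stands highest of the three measured numbers.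

Compound 4, `CC(C)=CCC/C(C)=C/CC1Cc2c(OCCCNC(=O)c3cccs3)cc(=O)n(CCCO)c2CC1(C)C`, has not yet been measured. Going by the values given here, it differs from compound 3 in that (thiophen-2-yl in place of furan-2-yl on a carbonyl carbon), which is the same change, at the same place on a carbonyl carbon whose other neighbour is the amide-type nitrogen, as the one that separates compound 1 from compound 2. That change occurs twice among these compounds. The step it made between compound 1 and compound 2 was large, so compound 4 is expected to sit above compound 3, but the number of compound 3 is already high and the read-out is a percentage with an upper end, so the step from compound 3 to compound 4 is expected to be smaller, around a number 15.5 percentage points higher from compound 3 to compound 4 (beyond the scatter). Compound 4 is therefore estimated to give about 85% in this assay, within a range of 65% to 100%.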

Compound 4, a percentage reported as inhibition, at one concentration (the size of the read-out at that concentration, not a potency): 72.8%
The estimate for compound 4 lay 12.2 percentage points above the measured number, and the stated range covers the measured number.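

In this assay, thiophen-2-yl in place of furan-2-yl on the carbonyl carbon gave a number 3.3 percentage points higher from compound 3 to compound 4 (within the scatter), so the change did not carry over from the core of compound 1 to the core of compound 3 at the same size: the same change on two cores in this assay, a number 31.5 percentage points higher (beyond the scatter) from compound 1 to compound 2 and a number 3.3 percentage points higher (within the scatter) from compound 3 to compound 4, 28.2 percentage points apart, beyond the scatter of two such steps. Read the other way, the added 3-methylbut-2-en-1-yl group still raised the number on the thiophen-2-yl compounds, with a number 39.2 percentage points higher from compound 2 to compound 4 (beyond the scatter), but this step too differed in size from the one seen with furan-2-yl: the same change on two cores in this assay, a number 67.4 percentage points higher (beyond the scatter) from compound 1 to compound 3 and a number 39.2 percentage points higher (beyond the scatter) from compound 2 to compound 4, 28.2 percentage points apart, beyond the scatter of two such steps. Going by these compounds alone, the two changes therefore did not simply add up in these four compounds, though this does not show why, nor whether the smaller steps have anything to do with the upper end of a percentage read-out, and with only two cores and one concentration it says nothing about potency or about how the exchange would behave on any further core.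

From the compounds shown here alone, it remains open whether a phenyl group or a pyridin-2-yl group on the carbonyl carbon would follow the furan-2-yl or the thiophen-2-yl compounds on either core. Going by these compounds, it is equally open whether a still longer chain in place of the 3-methylbut-2-en-1-yl extension would change the size of these steps.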